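From Hydroxy to Nitro: Expected Activity of Compound 4

The source may report more compounds than this note shows. Statements on the series, on what has been measured and on what is new or still open speak of the compounds shown alone.

Measured in a functional assay on A549 cells (Homo sapiens) for antiproliferative activity, read by MTT assay; on this read-out higher numbers stand for weaker inhibition and lower numbers for stronger inhibition:
Compound 1 `Cc1cccc(/C=N/Nc2ncc3c(n2)n(C2CCCC2)c(=O)c(=O)n3C)c1` gives 34500 nM.
Compound 2 `Cn1c(=O)c(=O)n(C2CCCC2)c2nc(N/N=C/c3ccc(O)c(F)c3)ncc21` gives 97800 nM.
Compound 3 `Cn1c(=O)c(=O)n(C2CCCC2)c2nc(N/N=C/c3cccc(O)c3)ncc21` gives > 100000 nM, which is a limit of the assay rather than a number.

Compound 3 therefore stands only at the limit of > 100000 nM in this assay, at which 1 of the 3 values shown sits. Compound 4 `Cn1c(=O)c(=O)n(C2CCCC2)c2nc(N/N=C/c3cccc([N+](=O)[O-])c3)ncc21` differs from it by nitro in place of hydroxy on an aromatic carbon. For the measured compounds named here, two measured steps touch compound 3: an at least 2.8-fold higher number from compound 1 to compound 3 (0.46 log units; beyond the scatter) shows that bringing in the hydroxy weakened inhibition, while an at least 1.0-fold higher number from compound 2 to compound 3 (0.00 log units; that floor lies within the scatter) lies within the scatter. Going by the values given here, no measured step brings in a nitro group, so the change itself is untested. Because compound 1 without the hydroxy gives 34500 nM, removing it may recover some inhibition. Compound 4 is expected near 60000 nM, within 20000 nM to 150000 nM. The expected step is an at least 1.6-fold lower number from compound 3 to compound 4 (0.22 log units; that floor lies within the scatter), with wide uncertainty.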

Compound 4, half-maximal inhibitory concentration: 12300 nM
Beside the measured number, compound 4's estimate is 4.9-fold (0.69 log units) above it; the measured number lies below the stated range.
By their numbers in this assay, from the lowest: compound 4; then compound 1; then compound 2. At a limit, above all of these: compound 3.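

In this assay this aromatic carbon can also carry a group that strengthens inhibition: nitro in place of methyl gives a 2.8-fold lower number from compound 1 to compound 4 (0.45 log units; beyond the scatter) and leaves compound 4 the strongest of the four. Against the two compounds with a hydroxy group, the 3-nitrophenyl group gives an 8.0-fold lower number from compound 2 to compound 4 (0.90 log units; beyond the scatter) and an at least 8.1-fold lower number from compound 3 to compound 4 (0.91 log units; beyond the scatter) as well. Compound 3 gives > 100000 nM as a limit of the assay and not a number.

From the compounds shown here alone, whether an amine or a carboxylic acid on this carbon would match the nitro group stays open. So does whether a second group on this ring would add to its effect.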